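Methyl to trifluoromethyl: notes on compound 2 and compound 4

This account rests on a few compounds, and the source may have more. Where it says the series, first, only, none or still open, it means among the compounds named here.

Three measured entries share one core: compound 1 (`O=C(c1ccc(C(F)(F)F)c(F)c1)c1ccc2nc(NC(=O)C(F)(F)F)cn2c1`), compound 2 (`Cc1ccc(F)c(C(=O)c2ccc3nc(NC(=O)C(F)(F)F)cn3c2)c1`) and compound 3 (`Cn1cc(C(=O)c2ccc3nc(NC(=O)C(F)(F)F)cn3c2)c2ccccc21`). Among the compounds with values here, in a functional assay on PC-3 cells (Homo sapiens) for cytotoxicity, read by sulforhodamine B assay, with a stated time of 48 h (a higher number here means a weaker inhibitor, a lower number a stronger inhibitor), compound 2 gives 69100 nM as the only number, so it has no numerical neighbour to be ranked against. Compound 1 is recorded as "not determined" (no result reported) in the same read-out. Compound 3 is likewise recorded as "not determined" (no result reported) in that read-out.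

Compound 4 (`O=C(c1ccc2nc(NC(=O)C(F)(F)F)cn2c1)c1cc(C(F)(F)F)ccc1F`) remains unmeasured. It differs from compound 2 by trifluoromethyl in place of methyl on an aromatic carbon. Within the data shown here, no step between measured compounds is available, so the series gives no guide to the size or direction of such a change in this assay at all. The expected step of a 1.2-fold lower number from compound 2 to compound 4 (0.06 log units; within the scatter) is therefore estimated to stay within the usual scatter, with no firm direction. This expectation rests solely on compound 2 at 69100 nM as the anchor. For compound 4 the estimated value is 60000 nM within an expected range of 20000 nM to 150000 nM for this measurement.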

Compound 4, half-maximal inhibitory concentration: 36300 nM
Beside the measured number, compound 4's estimate is 1.7-fold (0.22 log units) above it, within the range that was stated.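

In this assay the series now has one readable step: trifluoromethyl in place of methyl on an aromatic carbon, meta to a large group and para to a fluoro group, gives a 1.9-fold lower number from compound 2 to compound 4 (0.28 log units; within the scatter) and stays within the scatter. This exchange therefore does not separate the two compounds in this read-out, and the position takes either group with no step beyond the scatter. This rests on a single pair, so it sets no pattern for the series, and no measurement at hand bears on the reason for the result.

From the compounds shown here alone, it remains open whether an amine, a nitrile or a carboxylic acid on this aromatic carbon would give a step beyond the scatter in this assay. Going by these compounds, whether the same exchange behaves alike on another core also stays open.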